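The source may report more compounds than this note shows. Statements on the series, on what has been measured and on what is new or still open speak of the compounds shown alone.

Measured in a functional assay on A549 cells (Homo sapiens) for antiproliferative activity, read by MTT assay, with a stated time of 72 h; a higher number here means a weaker inhibitor, a lower number a stronger inhibitor:
- compound 1 `COc1cc2ncnc(Nc3cccc(Br)c3)c2cc1OCCCN1CCNCCNCC1`: 34300 nM
- compound 2 `COc1cc2ncnc(Nc3cccc(C(F)(F)F)c3)c2cc1OCCCN1CCNCCNCC1`: 37300 nM

Compound 2 gives 37300 nM and compound 1 gives 34300 nM, so the two values lie within the scatter of each other and no order can be read between them. Both compounds sit in the same range in this assay.

Next in the series is compound 3 `COc1cc2ncnc(Nc3ccc(Cl)cc3Cl)c2cc1OCCCN1CCNCCNCC1`, with 2,4-dichlorophenyl in place of 3-(trifluoromethyl)phenyl on a nitrogen on an aromatic ring.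

Among the measured compounds shown here, only one measured step bears on this change: a 1.1-fold higher number from compound 1 to compound 2 (0.04 log units; within the scatter), which swapped bromo for trifluoromethyl on an aromatic carbon and stayed within the scatter. For the measured compounds named here, that is thin support, since it covers a single substituent swap and no measured compound carries 2,4-dichlorophenyl. On that one step, no shift beyond the scatter is expected in this assay, and no direction can be favoured with confidence. The expected change is a 1.2-fold lower number from compound 2 to compound 3 (0.07 log units; within the scatter). For compound 3 the estimate is 32000 nM, with an expected range of 13000 nM to 75000 nM.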

Compound 3, half-maximal inhibitory concentration: 44200 nM
The estimate for compound 3 lay 1.4-fold (0.14 log units) below the measured number, within the range that was stated.
By their numbers in this assay, from the lowest: compounds 1, 2 and 3 (each within the scatter of the next).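

In this assay, 2,4-dichlorophenyl in place of 3-(trifluoromethyl)phenyl on a nitrogen on an aromatic ring gives a 1.2-fold higher number from compound 2 to compound 3 (0.07 log units; within the scatter), and the same group in place of 3-bromophenyl gives a 1.3-fold higher number from compound 1 to compound 3 (0.11 log units; within the scatter), so neither step can be read as a change in either direction. Among the compounds shown here, the earlier pair compared only two groups with a single substituent in the same place on the phenyl ring, whereas compound 3 alters both the substituent and where it sits, and its value still cannot be separated from those of compound 1 and compound 2. Across these three aryl groups, this nitrogen shows no measurable preference in this series, and no measurement at hand offers an explanation for that.

Going by these compounds, all three compounds share the same core and side chain, so it remains open whether a hydroxyl, an amino group or a carboxylic acid on the phenyl ring would move the value beyond the scatter. On these data alone, it also remains open whether the values depend on the large ring amine at the end of the side chain, which could be tested by putting a morpholine or a dimethylamino group in its place.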